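A few compounds are considered here, and "the series" means these few. Any claim that something is new, unique, unknown or untested is made for them only; others in the source may bear on it.

Measured so far:
compound 1 `Cc1cccc(COc2ccc(-c3nn(CCC#N)c(=S)o3)cc2)c1`, 66 nM
compound 2 `Cc1ccc(COc2ccc(-c3nn(CCC#N)c(=S)o3)cc2)cc1`, 400 nM
compound 3 `Cc1cccc(COc2ccc(C3=NN(CCC#N)C(=O)CO3)cc2)c1`, 31 nM

In an assay for inhibition of Amine oxidase [flavin-containing] B (Rattus norvegicus) (on this read-out higher numbers stand for weaker inhibition and lower numbers for stronger inhibition), compound 1 gives 66 nM and compound 2 gives 400 nM; the step of a 6.1-fold higher number from compound 1 to compound 2 (0.78 log units; beyond the scatter) goes with the change (4-methylphenyl in place of 3-methylphenyl on a saturated chain carbon bound to an oxygen on an aromatic ring). Compound 3 gives 31 nM, the lowest number of the three; how its core differs from the core of compound 1 is not broken down here. Compound 4 `Cc1ccc(COc2ccc(C3=NN(CCC#N)C(=O)CO3)cc2)cc1` has not yet been measured in this assay. It differs from compound 3 by 4-methylphenyl in place of 3-methylphenyl on a saturated chain carbon bound to an oxygen on an aromatic ring, the same change as between compound 1 and compound 2. In this assay, among the measured compounds shown here, the expected step is a 5.5-fold higher number from compound 3 to compound 4 (0.74 log units; beyond the scatter), because a 6.1-fold higher number from compound 1 to compound 2 (0.78 log units; beyond the scatter) is the one earlier instance of this change, and a single instance gives a wide range. Compound 4 is estimated at 170 nM, between 60 nM and 500 nM.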

Compound 4, half-maximal inhibitory concentration: 320 nM
Compound 4: the middle estimate sits 1.9-fold (0.27 log units) below what was measured; the range from low to high includes it.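

In this assay, 4-methylphenyl in place of 3-methylphenyl gives a 10-fold higher number from compound 3 to compound 4 (1.01 log units; beyond the scatter), so the number also rises on this second core. The change carries from one core to the other in direction and, within the scatter, in size: the same change on two cores in this assay, a 6.1-fold higher number (0.78 log units; beyond the scatter) from compound 1 to compound 2 and a 10-fold higher number (1.01 log units; beyond the scatter) from compound 3 to compound 4, 1.7-fold (0.23 log units) apart, within the scatter of two such steps. These two pairs show this for the two cores alone; they do not establish it for any other core, and they do not explain the step.

Open, going by these compounds, is whether an unsubstituted phenyl or an ethylphenyl would fit the same trend. Also open, on these data alone, is whether the step would persist with a carboxylic acid or an amine in place of the nitrile.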